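A few compounds are considered here, and "the series" means these few. Any claim that something is new, unique, unknown or untested is made for them only; others in the source may bear on it.

Compound 3, `O=C(O)CNC(=O)c1c(O)c2c(n(Cc3nc(C(F)(F)F)cs3)c1=O)COC2`, is measured in an assay on Sf9 cells for inhibition of prolyl hydroxylase EGLN2 (Homo sapiens), read by TR-FRET, with stated times of 30 min and 2 h (on this read-out higher numbers stand for weaker inhibition and lower numbers for stronger inhibition), where compound 3 gives 3.7 nM. Among the three compounds measured so far, compound 3 gives the highest number, but no gap here is beyond the scatter: compound 2, `O=C(O)CNC(=O)c1c(O)c2c(n(Cc3cnc(C(F)(F)F)s3)c1=O)COC2`, gives 2.4 nM in this assay, and compound 1, `O=C(O)CNC(=O)c1c(O)c2c(n(Cc3ccc(F)cc3F)c1=O)COC2`, gives 2.2 nM. The three steps that connect them are all small: a 1.1-fold higher number from compound 1 to compound 2 (0.04 log units; within the scatter), a 1.7-fold higher number from compound 1 to compound 3 (0.23 log units; within the scatter) and a 1.5-fold higher number from compound 2 to compound 3 (0.19 log units; within the scatter). Each of these steps swaps one aromatic group on a saturated chain carbon bound to an aromatic nitrogen, and none of them moves the number beyond the scatter.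

Compound 4, `O=C(O)CNC(=O)c1c(O)c2c(n(Cc3nc4ccccc4o3)c1=O)COC2`, is not yet measured. Its difference from compound 3 is 1,3-benzoxazol-2-yl in place of 4-(trifluoromethyl)-1,3-thiazol-2-yl on a saturated chain carbon bound to an aromatic nitrogen. This is the same kind of swap as the three measured steps, so the expectation for compound 4 in this assay is a step that stays within the scatter, with no clear direction. Compound 4 is therefore estimated at 4 nM, with a range from 1.5 nM to 11 nM. Against compound 3, this estimate means a 1.1-fold higher number from compound 3 to compound 4 (0.03 log units; within the scatter).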

Compound 4, half-maximal inhibitory concentration: 5 nM
Beside the measured number, compound 4's estimate is 1.3-fold (0.10 log units) below it; measured number inside the range.
By their numbers in this assay, from the lowest: compounds 1, 2, 3 and 4 (each within the scatter of the next, the first and the last beyond it).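

In this assay, the 1,3-benzoxazol-2-yl group, the first shown here with two aromatic rings, gives a 1.4-fold higher number from compound 3 to compound 4 (0.13 log units; within the scatter). Yet it also produces the first steps at this position that pass the scatter, though only modestly: a 2.1-fold higher number from compound 2 to compound 4 (0.32 log units; beyond the scatter) and a 2.3-fold higher number from compound 1 to compound 4 (0.36 log units; beyond the scatter). So the group on a saturated chain carbon bound to an aromatic nitrogen can shift the number a little, and nothing available here bears on why.

The compounds shown leave open whether the shift goes with the second aromatic ring, with oxygen in the ring instead of sulfur, or with the absence of trifluoromethyl. They also leave open what happens at this position with a group that has no aromatic ring, such as a cyclohexyl ring or a chain ending in an amine.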